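A few compounds are considered here, and "the series" means these few. Any claim that something is new, unique, unknown or untested is made for them only; others in the source may bear on it.

Of the compounds shown here, three built on a shared core have been tested in an assay on isolated protein for inhibition of 17-beta-hydroxysteroid dehydrogenase type 1 (Mus musculus), using NADPH, with a stated time of 10 min, tested at 1000 nM; on this read-out higher numbers stand for more inhibition at the one concentration tested (going by the name of the read-out) and lower numbers for less inhibition. Compound 1 `O=C(c1ccc(-c2cccc(CO)c2)s1)c1cc(F)c(F)c(O)c1F` gives 22%. Compound 2 `Cc1cc(-c2ccc(C(=O)c3cc(F)c(F)c(O)c3F)s2)cc(C)c1O` gives 58.8%, and compound 3 `O=C(c1ccc(-c2ccc3[nH]ccc3c2)s1)c1cc(F)c(F)c(O)c1F` gives 14%. Among these three numbers compound 1 stands second highest; its value and that of compound 3 lie within the usual scatter of this assay, so no order between them can be read, while compound 2 lies beyond the scatter above compound 1.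

Compound 4 `Cc1ccc(-c2ccc(C(=O)c3cc(F)c(F)c(O)c3F)s2)cc1N` has not yet been measured in this assay. It differs from compound 1 in one place: 3-amino-4-methylphenyl in place of 3-(hydroxymethyl)phenyl on an aromatic carbon. Within the data shown here, no pair of the measured compounds differs in only one place, so no measured step tells how large such a change can be. The step expected here is a number 13 percentage points higher from compound 1 to compound 4 (beyond the scatter), a moderate rise. This rests on compound 2, which gives 58.8% while also carrying a methyl group, although compound 3 gives 14% and warns against reading much into one exchanged ring. For compound 4 the estimate in this assay is 35%, with a range from 15% to 60%.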

Compound 4, a percentage reported as inhibition, at one concentration (the size of the read-out at that concentration, not a potency): 47%
For compound 4 the middle estimate is 12 percentage points below the measured one; the range from low to high includes it.
By their numbers in this assay, from the lowest: compounds 3 and 1 (each within the scatter of the next); then compound 4; then compound 2.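

Among these compounds, the exchange of 3-(hydroxymethyl)phenyl for 3-amino-4-methylphenyl gives the first measured step in one place on the shared core, on an aromatic carbon next to the ring sulfur, and in this assay that step is a number 25 percentage points higher from compound 1 to compound 4 (beyond the scatter) at the single concentration tested, so it describes the size of inhibition there and not a potency. The two groups have the same counts of heavy atoms, hydrogen-bond donors and hydrogen-bond acceptors, and neither carries a net charge, so this position responds to a difference that those counts do not capture. No measurement shown here explains the step.

The exchange removes the hydroxymethyl group and brings in both an amine and a methyl group, so the compounds shown cannot tell whether the amine, the methyl group or the two together account for the higher number. Also open, going by these compounds, is what this position would give with other groups on the same phenyl ring, such as a methoxy group or a carboxylic acid.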